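Swapping the aromatic cap for a cyclopentyl ring

This account rests on a few compounds, and the source may have more. Where it says the series, first, only, none or still open, it means among the compounds named here.

Compound 3 `Cc1cccc(Cn2c(CN3CCN(C(=O)c4cccs4)CC3)nc3ccccc32)c1` sits second highest of the three compounds measured in an assay on isolated protein for inhibition of aldehyde dehydrogenase 1A1 (Homo sapiens), read by spectrophotometry, tested at 10 uM (on this read-out lower numbers stand for less inhibition and higher numbers for more inhibition at the one concentration tested (going by the name of the read-out)), where compound 3 gives 60.8%. Compound 2 `CCC(=O)N1CCN(Cc2nc3ccccc3n2Cc2cccc(C)c2)CC1` gives 85.1% and compound 1 `Cc1cccc(Cn2c(CN3CCN(C(=O)c4ccc([N+](=O)[O-])cc4)CC3)nc3ccccc32)c1` gives 24.3%. Compound 4 `Cc1cccc(Cn2c(CN3CCN(C(=O)C4CCCC4)CC3)nc3ccccc32)c1` differs from compound 3 by cyclopentyl in place of thiophen-2-yl on a carbonyl carbon. The most relevant step is a number 24.3 percentage points lower from compound 2 to compound 3 (beyond the scatter), which shows that the number is higher with a small saturated group on that carbonyl carbon than with the aromatic one; a number 36.5 percentage points higher from compound 1 to compound 3 (beyond the scatter) and a number 60.8 percentage points higher from compound 1 to compound 2 (beyond the scatter) point the same way. Compound 4 is therefore expected to rise by a number 14.2 percentage points higher from compound 3 to compound 4 (beyond the scatter) in this assay. The estimate for compound 4 is 75%, with a range from 55% to 92%.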

Compound 4, a percentage reported as inhibition, at one concentration (the size of the read-out at that concentration, not a potency): 67.5%
The estimate for compound 4 lay 7.5 percentage points above the measured number; the range from low to high includes it.
By their numbers in this assay, from the lowest: compound 1; then compounds 3 and 4 (each within the scatter of the next); then compound 2.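

In this assay, exchanging the aromatic thiophen-2-yl for the non-aromatic cyclopentyl on this carbonyl carbon gives no readable difference (a number 6.7 percentage points higher from compound 3 to compound 4 (within the scatter)), so the aromatic ring alone does not separate these two caps. The ethyl compound still stands apart (a number 17.6 percentage points lower from compound 2 to compound 4 (beyond the scatter)), as does the 4-nitrophenyl compound (a number 43.2 percentage points higher from compound 1 to compound 4 (beyond the scatter)). No evidence available here explains these differences.

As far as these compounds go, it remains open whether an amine, a carboxylic acid or a chain longer than ethyl at this place would keep the number high. From the compounds shown here alone, it is also open whether a cyclopropyl ring would read like ethyl or like cyclopentyl.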